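Urea aryl variation in the shared core, next step

The compounds below may be only part of what the source reports. "The series", "measured", "known", "first", "only" and "open" are said of these compounds alone.

Three compounds of the series carry the same core and differ only in the aryl group on the urea. Compound 1 `COc1cc(Cl)cc(-c2nn(-c3cccc(NC(=O)Nc4ccc(Cl)c(C(F)(F)F)c4)c3)cc2-c2ccncc2)c1` gives -30% in a functional assay on SR cells (Homo sapiens) for inhibition, read by sulforhodamine B assay, with a stated time of 48 h, tested at 100 uM; on this read-out higher numbers stand for a weaker effect at the one concentration tested and lower numbers for a stronger effect. Compound 2 `COc1cc(Cl)cc(-c2nn(-c3cccc(NC(=O)Nc4cc(C(F)(F)F)cc(C(F)(F)F)c4)c3)cc2-c2ccncc2)c1` gives -8% in this assay. Compound 3 `COc1cc(Cl)cc(-c2nn(-c3cccc(NC(=O)Nc4ccc(Cl)c(Cl)c4)c3)cc2-c2ccncc2)c1` gives -26% in this assay; it stands second highest of the three numbers, nearest to compound 1 and furthest from compound 2.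

For the measured compounds named here, the only single-point step measured so far is a number 4 percentage points higher from compound 1 to compound 3 (within the scatter), so swapping chloro and trifluoromethyl on the aromatic carbon of the urea aryl left the read-out unchanged within the scatter. Compound 4 `COc1cc(Cl)cc(-c2nn(-c3cccc(NC(=O)Nc4cccc(C(F)(F)F)c4)c3)cc2-c2ccncc2)c1` is the next step from compound 3: 3-(trifluoromethyl)phenyl in place of 3,4-dichlorophenyl on an amide-type nitrogen. Here one of the two ring substituents falls away rather than being exchanged, and no measured pair shows a step of that kind. Compound 2, with two trifluoromethyl groups on that ring, sits higher than compounds 1 and 3, which is the only hint that the pattern of ring substituents matters in this assay.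

On this basis the step of a number 8 percentage points higher from compound 3 to compound 4 (within the scatter) is expected to be small, leaning toward a higher number. Compound 4 is estimated at -18%, within -38% to 2%.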

Compound 4, a percentage reported as activity, at one concentration (the size of the read-out at that concentration, not a potency): -30%
Estimate against measurement, compound 4: 12 percentage points above, within the range that was stated.
By their numbers in this assay, from the lowest: compounds 1, 4 and 3 (each within the scatter of the next); then compound 2.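

In this assay, the ring on the amide-type nitrogen tolerates the loss of a substituent in two of the three comparisons: there is no change at the digits printed from compound 1 to compound 4 (within the scatter) when hydrogen replaces chloro, and a number 4 percentage points lower from compound 3 to compound 4 (within the scatter) when 3-(trifluoromethyl)phenyl replaces 3,4-dichlorophenyl. For the compounds shown here, removing a trifluoromethyl is different, with a number 22 percentage points lower from compound 2 to compound 4 (beyond the scatter) as the first single-point step that lies beyond the scatter, although it is modest. The second substituent therefore matters here only when it is the additional trifluoromethyl of compound 2, whereas the chloro of compound 1 and the 3,4-dichloro pattern of compound 3 give read-outs within the scatter of compound 4, and compound 2 remains the exception among these four.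

Still open, as far as these compounds go, is whether the read-out would hold with an unsubstituted phenyl, or with a methoxy, a dimethylamino group or a carboxylic acid on that ring. Nothing available accounts for why one substituent exchange moves the read-out and the others do not.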